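The compounds below may be only part of what the source reports. "The series", "measured", "known", "first", "only" and "open" are said of these compounds alone.

Among the compounds with values here, compound 2 `c1ccc2nc(COc3ccc(SCCCc4nnn[nH]4)cc3)ccc2c1` stands lowest of the two numbers so far: in a functional assay (Cavia porcellus) for inhibition of cysteinyl leukotriene receptor (Homo sapiens) (on this read-out lower numbers stand for stronger inhibition and higher numbers for weaker inhibition), compound 2 gives 25 nM. Within the data shown here, the only other measured member, compound 1 `c1ccc2nc(COc3ccc(Cc4nnn[nH]4)cc3)ccc2c1`, gives 1000 nM in this assay, and the sole measured step, a 40-fold lower number from compound 1 to compound 2 (1.60 log units; beyond the scatter), came from lengthening the side chain rather than from changing the atom that joins it to the ring. Compound 3 `c1ccc2nc(COc3ccc(OCCCc4nnn[nH]4)cc3)ccc2c1` keeps the lengthened chain of compound 2 and differs from it only by a group of 9 heavy atoms (4 carbon, 4 nitrogen, 1 oxygen; one five-membered aromatic ring with 4 hetero atoms) in place of a group of 9 heavy atoms (4 carbon, 4 nitrogen, 1 sulfur; one five-membered aromatic ring with 4 hetero atoms), on an aromatic carbon. Among the measured compounds shown here, no measured pair tests an exchange of sulfur for oxygen in that linker, so the large step from compound 1 to compound 2 says little about it. A step in this assay no larger than the scatter, in either direction, is expected from compound 2 to compound 3, about a 1.2-fold higher number from compound 2 to compound 3 (0.08 log units; within the scatter). Compound 3 is therefore estimated at 30 nM, within a range from 8 nM to 120 nM.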

Compound 3, half-maximal inhibitory concentration: 250 nM
For compound 3 the middle estimate is 8.3-fold (0.92 log units) below the measured one; measured number above the stated range.
By their numbers in this assay, from the lowest: compound 2; then compound 3; then compound 1.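

Within this assay the atom that joins the side chain to the ring counts on its own: with the chain length held, sulfur to oxygen gives a 10-fold higher number from compound 2 to compound 3 (1.00 log units; beyond the scatter) and so sets these two linkers apart. The 3-(1H-tetrazol-5-yl)propoxy group in place of (1H-tetrazol-5-yl)methyl still gives a 4.0-fold lower number from compound 1 to compound 3 (0.60 log units; beyond the scatter), a smaller gain than a 40-fold lower number from compound 1 to compound 2 (1.60 log units; beyond the scatter), so the lengthened chain alone does not carry the whole of the earlier step, and the sulfur linker accounts for the rest in this set. No measurement at hand bears on why the two linking atoms differ.

Going by these compounds, whether a methylene as the linking atom would track the sulfur or the oxygen compound remains open. Also open, on these data alone, is whether the sulfur advantage holds with a longer chain or with a carboxylic acid in place of the tetrazole.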